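Replacing iodo with trifluoromethoxy on a growth-inhibiting compound

The source may hold more compounds than are shown below. What is called first, only, known or untested is meant among the compounds shown, and "the series" means these compounds.

In a functional assay on DU-145 cells (Homo sapiens) for inhibition, read by trypan blue exclusion, with a stated time of 96 h (on this read-out higher numbers stand for weaker inhibition of growth and lower numbers for stronger inhibition of growth), compound 1 `O=C(/C(=C\c1ccc(Br)cc1)Sc1ccc(Br)cc1)c1ccc(Br)cc1` gives 1000 nM and compound 2 `O=C(/C(=C\c1ccc(I)cc1)Sc1ccc(Br)cc1)c1ccc(Br)cc1` gives 1000 nM in the same test, so compound 2 stands level with compound 1 at the digits reported. Compound 3 `O=C(/C(=C\c1ccc(OC(F)(F)F)cc1)Sc1ccc(Br)cc1)c1ccc(Br)cc1` differs from compound 2 in one place, with trifluoromethoxy in place of iodo on an aromatic carbon. Within the data shown here, only one measured step bears on this change. It is no change at the digits printed from compound 1 to compound 2 (within the scatter) for iodo in place of bromo on that same aromatic carbon, so swapping one halogen for another left the number where it was. Among the measured compounds shown here, no measured compound carries trifluoromethoxy, which is not a halogen, so this step is only a loose guide and the range has to stay wide. The expectation rests on compound 2 at 1000 nM and on that one step. The expected step is no change at the digits printed from compound 2 to compound 3 (within the scatter) in this assay with no shift beyond the scatter foreseen. Compound 3 is estimated at 1000 nM with an expected range of 400 nM to 2500 nM on this read-out.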

Compound 3, concentration for 50% growth inhibition: 10000 nM
Estimate against measurement, compound 3: 10-fold (1.00 log units) below, outside the stated range (above it).
By their numbers in this assay, from the lowest: compounds 1 and 2 (each within the scatter of the next); then compound 3.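

Until now this aromatic carbon, para to a large group, had carried only halogens, and bromo and iodo there gave the same number. In this assay, the position now proves sensitive to what it carries, with a 10-fold higher number from compound 2 to compound 3 (1.00 log units; beyond the scatter) for trifluoromethoxy in place of iodo and a 10-fold higher number from compound 1 to compound 3 (1.00 log units; beyond the scatter) for trifluoromethoxy in place of bromo, both steps towards weaker inhibition of growth, so the agreement between the two halogens does not extend to this group, which has 5 heavy atoms and 1 hydrogen-bond acceptor where iodo has 1 heavy atom and 0 hydrogen-bond acceptors. Nothing in the data speaks to why the number rises, so neither the size of the entering group nor its oxygen can be singled out.

Still open, on these data alone, is whether methoxy, an amine or a carboxylic acid on this same carbon would stay level with compound 1 and compound 2 or move the number further. Also open, as far as these compounds go, is whether trifluoromethoxy in place of bromo elsewhere on the shared core would give a step of similar size.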